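Swapping the aryl sulfone of compound 3 for a fluorinated ring

The source may report more compounds than this note shows. Statements on the series, on what has been measured and on what is new or still open speak of the compounds shown alone.

Compound 1 `CC1CCN(c2c(S(=O)(=O)c3cccc(F)c3)cnc3ccc(Cl)cc23)CC1` gives 58% in an assay on isolated protein for displacement of a labelled ligand from metabotropic glutamate receptor 5 (Homo sapiens), with a stated time of 60 min, tested at 1 uM; a higher number here means more inhibition at the concentration tested (going by the name of the read-out), a lower number less inhibition.
Compound 2 `COc1ccc(S(=O)(=O)c2cnc3ccc(C)cc3c2N2CCC(C)CC2)cc1Cl` gives 93% in this assay.
Compound 3 `Cc1cc(C)cc(S(=O)(=O)c2cnc3cc(F)ccc3c2N2CCC(C)CC2)c1` gives 80% in this assay.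

Compound 3 stands second highest of the three numbers: compound 2 sits above it beyond the scatter, and compound 1 sits below it beyond the scatter. Compound 4 `Cc1ccc(S(=O)(=O)c2cnc3cc(F)ccc3c2N2CCC(C)CC2)cc1F` differs from compound 3 in one place: 3-fluoro-4-methylphenyl in place of 3,5-dimethylphenyl on a sulfonyl sulfur. The leaving and entering groups have the same count of heavy atoms, so the change is a small one. Among the measured compounds shown here, no measured pair shows this change, and the three values give no guide to its direction. A step within the scatter, or a slight loss, is expected from compound 3 to compound 4, namely a number 5 percentage points lower from compound 3 to compound 4 (within the scatter). Compound 4 is therefore expected to reach 75% in this assay, between 55% and 92%.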

Compound 4, a percentage reported as inhibition, at one concentration (the size of the read-out at that concentration, not a potency): 89%
Compound 4: middle estimate off by 14 percentage points, on the low side; measured number inside the range.
By their numbers in this assay, from the lowest: compound 1; then compounds 3, 4 and 2 (each within the scatter of the next, the first and the last beyond it).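

Among the compounds shown here, this pair gives the first reading of a single change in the group on the sulfonyl sulfur. In this assay, 3-fluoro-4-methylphenyl in place of 3,5-dimethylphenyl gives a number 9 percentage points higher from compound 3 to compound 4 (within the scatter) and so shows that this position accepts the exchange of these two equally sized aryl groups with no step beyond the scatter. No measurement shown offers an explanation for this result. One pair cannot show whether the same holds on other cores. From the compounds shown here alone, how a pyridyl ring or a cyclohexyl group on the sulfonyl sulfur would read in this assay remains open.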